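Replacing 3,5-dimethoxyphenyl: from compound 2 to compound 4

A few compounds are considered here, and "the series" means these few. Any claim that something is new, unique, unknown or untested is made for them only; others in the source may bear on it.

Values in a functional assay on HCT-116 cells (Homo sapiens) for cytotoxicity, read by MTT assay, with a stated time of 72 h; a lower number here means a stronger inhibitor, a higher number a weaker inhibitor:
- Compound 1 `COc1cc(Nc2nc3ccccc3nc2S(=O)(=O)c2ccccc2)cc(OC)c1`: 950 nM
- Compound 2 `COc1ccc(S(=O)(=O)c2nc3ccccc3nc2Nc2cc(OC)cc(OC)c2)cc1`: 13400 nM
- Compound 3 `COc1ccc(S(=O)(=O)c2nc3ccccc3nc2Nc2cc(OC)c(OC)c(OC)c2)cc1`: > 50000 nM, a limit

Compound 2 holds the higher of the two actual numbers, and compound 1 is its nearest neighbour. Compound 4 `COc1ccc(S(=O)(=O)c2nc3ccccc3nc2Nc2ccc(C(F)(F)F)cc2)cc1`, not yet measured, carries 4-(trifluoromethyl)phenyl in place of 3,5-dimethoxyphenyl on a nitrogen on an aromatic ring. Within the data shown here, two measured steps bear on this, each methoxy in place of hydrogen on an aromatic carbon: a 14-fold higher number from compound 1 to compound 2 (1.15 log units; beyond the scatter) and an at least 3.7-fold higher number from compound 2 to compound 3 (0.57 log units; beyond the scatter). Both go upward, so losing methoxy groups points to a lower number in this assay. Among the measured compounds shown here, no measured compound carries trifluoromethyl, so this guide is loose. The expected step is a 2.2-fold lower number from compound 2 to compound 4 (0.35 log units; beyond the scatter). For compound 4 the estimate is 6000 nM, with an expected range of 1500 nM to 25000 nM.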

Compound 4, half-maximal inhibitory concentration: 110 nM
Estimate against measurement, compound 4: 55-fold (1.74 log units) above, outside the stated range (below it).
By their numbers in this assay, from the lowest: compound 4; then compound 1; then compound 2. At a limit, above all of these: compound 3.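

In this assay, 4-(trifluoromethyl)phenyl in place of 3,5-dimethoxyphenyl on a nitrogen on an aromatic ring gives a 120-fold lower number from compound 2 to compound 4 (2.09 log units; beyond the scatter). The earlier compounds shown here varied only methoxy groups; compound 4 shows that this position needs no methoxy for a low number, and its entering group counts no hydrogen-bond acceptors. Nothing shown accounts for the size of this step.

Open, from the compounds shown here alone, is how much of the step comes from losing the methoxy groups and how much from gaining trifluoromethyl. Also open, going by these compounds, is whether a plain phenyl, or a phenyl carrying a nitrile or an amine, would behave like compound 4.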